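From 3-Methoxyphenyl to 2,4-Difluorobenzyl on the Amide Nitrogen

The source may report more compounds than this note shows. Statements on the series, on what has been measured and on what is new or still open speak of the compounds shown alone.

For the measured compounds named here, compound 1 `COc1cccc(NC(=O)/C=C/c2coc3cc(OC)ccc3c2=O)c1` is the only compound here with a measured number: in a functional assay on A549 cells (Homo sapiens) for inhibition, read by MTT assay, with a stated time of 48 h (on this read-out lower numbers stand for stronger inhibition and higher numbers for weaker inhibition), compound 1 gives 12800 nM. Compound 2 `Cc1ccccc1NC(=O)/C=C/c1coc2cc(O)ccc2c1=O` reaches only a limit of this assay, > 100000 nM; this is the limit of > 100000 nM in this assay, at which 1 of the 2 values shown sits. Compound 3 `COc1ccc2c(=O)c(/C=C/C(=O)NCc3ccc(F)cc3F)coc2c1` differs from compound 1 in one place: 2,4-difluorobenzyl in place of 3-methoxyphenyl on an amide-type nitrogen. Going by the values given here, no measured step between compounds informs this change, so in this assay no shift beyond the scatter is expected in either direction. Compound 3 is therefore estimated at 15000 nM, within 4000 nM to 60000 nM, and the expected step of a 1.2-fold higher number from compound 1 to compound 3 (0.07 log units; within the scatter) is accordingly small.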

Compound 3, half-maximal inhibitory concentration: 13300 nM
Beside the measured number, compound 3's estimate is 1.1-fold (0.05 log units) above it; the measured number falls inside the stated range.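

The exchange of 3-methoxyphenyl for 2,4-difluorobenzyl on the amide-type nitrogen now has a measured step in this assay (a 1.0-fold higher number from compound 1 to compound 3 (0.02 log units; within the scatter)), where none informed this position before. The hydrogen-bond acceptor counted in 3-methoxyphenyl is absent from 2,4-difluorobenzyl, yet compound 1 and compound 3 remain within the scatter of each other. Nothing shown here offers a reason for this result. From the compounds shown here alone, whether an amine, a carboxylic acid or a longer alkyl chain on this nitrogen would give a step beyond the scatter remains open.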